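The source may report more compounds than this note shows. Statements on the series, on what has been measured and on what is new or still open speak of the compounds shown alone.

In a functional assay on MCF7 cells (Homo sapiens) for antiproliferative activity, read by MTT assay, with a stated time of 72 h (on this read-out lower numbers stand for stronger inhibition and higher numbers for weaker inhibition), compound 1 `COc1ccc(-c2ncnn2-c2cc(OC)c(OC)c(OC)c2)cc1` gives 360 nM. Compound 2 `CCOc1cccc(-c2ncnn2-c2cc(OC)c(OC)c(OC)c2)c1` gives > 10000 nM, which is a limit of this assay and not a number. Compound 3 `COc1cc(-n2ncnc2-c2cccc(F)c2)cc(OC)c1OC` carries fluoro in place of the ethoxy of compound 2, on an aromatic carbon, meta to a large group: fluoro in place of ethoxy on an aromatic carbon. Within the data shown here, no measured pair isolates this change, so any forecast is loose. Compound 1 at 360 nM shows that a close relative can register a number well inside the range of this assay. A shift toward stronger inhibition is therefore expected, with the estimated step of an at least 4.0-fold lower number from compound 2 to compound 3 (0.60 log units; beyond the scatter). For compound 3 the expected value is 2500 nM, within an estimated range of 300 nM to 10000 nM.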

Compound 3, half-maximal inhibitory concentration: > 10000 nM
Compound 3: a limit, no number; the forecaster's own chance of this, stated with the estimate: 25%; at least 4.0-fold (0.60 log units) between middle value and limit.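

Fluoro in place of ethoxy, meta to a large group, brings no readable number: compound 3 gives > 10000 nM, which is a limit of the assay and not a number. The step between compound 2 and compound 3 cannot be read, because both stop at the same limit: the limit of > 10000 nM in this assay, at which 2 of the 3 values shown sit. Replacing 4-methoxyphenyl with 3-fluorophenyl, however, gives an at least 27-fold higher number from compound 1 to compound 3 (1.44 log units; beyond the scatter), a large loss of activity. As far as these compounds go, compound 1 and compound 3 differ in both the group and its place on the ring, so it remains open which of these matters. From the compounds shown here alone, it is also open whether an amine at this meta place would return a number within the range of the assay.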